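Amide Methyl to Hydrogen in an Orexin 2 Agonist Series

The compounds below may be only part of what the source reports. "The series", "measured", "known", "first", "only" and "open" are said of these compounds alone.

Compound 3 `COc1ccc(-c2cccc(C(=O)N(C)Cc3ccccn3)c2)cc1S(=O)(=O)Nc1cccc(NCCNC(=O)c2cccc(C)c2)c1` gives 76% in a functional assay on CHO-RD-HGA16 cells for agonist activity at Orexin receptor type 2 (Homo sapiens), read by fluorescence and calcium flux, with a stated time of 30 min (a lower number here means a smaller maximal response, a higher number a larger maximal response), the second highest of the three measured values: its nearest neighbour is compound 1 `COc1ccc(-c2cccc(C(=O)N(C)CCN(C)C)c2)cc1S(=O)(=O)Nc1cccc(NCCNC(=O)c2cccc(C)c2)c1`, which gives 85%, and this gap lies within the scatter, whereas compound 2 `COc1ccc(-c2cccc(C(=O)NCCN(C)C)c2)cc1S(=O)(=O)Nc1cccc(NCCNC(=O)c2cccc(C)c2)c1` gives 64% and sits further off, beyond the scatter. Compound 4 `COc1ccc(-c2cccc(C(=O)NCc3ccccn3)c2)cc1S(=O)(=O)Nc1cccc(NCCNC(=O)c2cccc(C)c2)c1` is not yet measured; it differs from compound 3 by hydrogen in place of methyl on an amide-type nitrogen.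

Going by the values given here, the one measured step of the same kind is a number 21 percentage points lower from compound 1 to compound 2 (beyond the scatter), where the methyl on the amide-type nitrogen was likewise replaced by hydrogen. The related step of a number 12 percentage points higher from compound 2 to compound 3 (beyond the scatter) changed both the methyl and the chain, so it bears on this question only in part. A modest drop in maximal response is therefore expected for compound 4, of about a number 18 percentage points lower from compound 3 to compound 4 (beyond the scatter). Compound 4 is estimated to reach 58% in this assay, with a range from 40% to 76%.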

Compound 4, largest response reached (Emax), in percent of the reference or control that the assay uses: 22%
Beside the measured number, compound 4's estimate is 36 percentage points above it; measured number outside the range, below it.
By their numbers in this assay, from the lowest: compound 4; then compound 2; then compounds 3 and 1 (each within the scatter of the next).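

In this assay the step of a number 54 percentage points lower from compound 3 to compound 4 (beyond the scatter) is large, so hydrogen in place of methyl on the amide-type nitrogen carries no fixed cost in this series. The size of this change depends on what the saturated chain carries: the same change on two cores in this assay, a number 21 percentage points lower (beyond the scatter) from compound 1 to compound 2 and a number 54 percentage points lower (beyond the scatter) from compound 3 to compound 4, 33 percentage points apart, beyond the scatter of two such steps. Read the other way, pyridin-2-yl in place of (dimethylamino)methyl stays within the scatter only while the methyl is present, for without the methyl the step is a number 42 percentage points lower from compound 2 to compound 4 (beyond the scatter), and the two changes together give a number 63 percentage points lower from compound 1 to compound 4 (beyond the scatter): the same change on two cores in this assay, a number 9 percentage points lower (within the scatter) from compound 1 to compound 3 and a number 42 percentage points lower (beyond the scatter) from compound 2 to compound 4, 33 percentage points apart, beyond the scatter of two such steps.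

These four compounds leave open whether this dependence is particular to pyridin-2-yl or would also hold for another chain end, such as a morpholine or a carboxylic acid. They also leave open how the maximal response would change with an ethyl in place of the methyl on this nitrogen.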